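The source may hold more compounds than are shown below. What is called first, only, known or untested is meant among the compounds shown, and "the series" means these compounds.

Series notes. In a physicochemical assay for lipophilicity, read by HPLC, in phosphate buffer, measured as octanol-water partition, at pH 7.4, tested at 100 uM (on this read-out higher numbers stand for higher lipophilicity and lower numbers for lower lipophilicity), compound 3 (`CCCOc1ccc(-c2cccc(CNc3ccc(OCC(=O)O)c(F)c3)c2)c(C)c1`) gives 3.37. Compound 2 (`CCCOc1cc(C)c(-c2cccc(CNc3ccc(OCC(=O)O)c(F)c3)c2)c(C)c1`) gives 3.59, within the scatter of compound 3, so the two numbers cannot be ranked. Compound 1 (`CCOc1cc(C)c(-c2cccc(COc3ccc(NCC(=O)O)c(F)c3)c2)c(C)c1`) adds no number to the comparison, its entry being "not determined" (no result reported).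

The next compound to be measured is compound 4 (`Cc1cc(OCCO)ccc1-c1cccc(CNc2ccc(OCC(=O)O)c(F)c2)c1`). Its change from compound 3 is hydroxy in place of methyl on a saturated chain carbon, two bonds along the chain from an oxygen on an aromatic ring. The same difference reads as propoxy to 2-hydroxyethoxy.

Among the measured compounds shown here, only one measured step is available, a number 0.22 log units lower from compound 2 to compound 3 (within the scatter). That step is hydrogen in place of methyl on an aromatic carbon, a different change at a different place, so it gives no direct measure of the size to expect here. For the measured compounds named here, no measured pair carries the propoxy to 2-hydroxyethoxy change, and the expectation therefore rests on the structural change itself, starting from compound 3 at 3.37. The expected step, beyond the scatter, is a number 1.07 log units lower from compound 3 to compound 4 (beyond the scatter). In this assay the estimate for compound 4 is 2.3, with an expected range from 1.8 to 2.8.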

Compound 4, distribution coefficient: 1.65
Compound 4: middle estimate off by 0.65 log units, on the high side; the measured number lies below the stated range.
By their numbers in this assay, from the lowest: compound 4; then compounds 3 and 2 (each within the scatter of the next).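

Hydroxy in place of methyl on a saturated chain carbon, two bonds along the chain from an oxygen on an aromatic ring, gives a number 1.72 log units lower from compound 3 to compound 4 (beyond the scatter) in this assay and is the first step in the series that can be read as a real difference, whereas the only earlier step, hydrogen in place of methyl on an aromatic carbon, stayed within the scatter. This place on the propoxy chain therefore answers strongly to a swap of a single heavy atom, one that adds 1 hydrogen-bond donor and 1 hydrogen-bond acceptor while the rest of the structure stays the same. Nothing measured accounts for the size of this step.

On these data alone, the change rests on one pair, so it remains open whether a similar step would appear with the two methyl groups of compound 2 on the same ring. As far as these compounds go, it is also open how a methoxy, an amine or a carboxylic acid at this place would compare with hydroxy, and whether a longer chain carrying the hydroxy would give back part of the difference.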